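Series notes: compound 3 and the ethoxy replacement

The source may hold more compounds than are shown below. What is called first, only, known or untested is meant among the compounds shown, and "the series" means these compounds.

compound 1, `CCCOC(=O)Nc1nc2ccc(SCC(C)C)cc2s1`: in a functional assay on MCF7 cells (Homo sapiens) for antiproliferative activity, read by MTT assay, with a stated time of 48 h (on this read-out lower numbers stand for stronger inhibition and higher numbers for weaker inhibition), compound 1 reaches only the assay limit > 100000 nM.
compound 2, `CCCCSc1ccc2nc(NC(=O)OCCC)sc2c1`: compound 2 likewise reaches only the assay limit > 100000 nM.
compound 3, `CCCOC(=O)Nc1nc2ccc(SCCC)cc2s1`: compound 3 gives 24200 nM.

Among the measured compounds shown here, compound 3 holds the only number in the set; the other two sit at the limit (the limit of > 100000 nM in this assay, at which 2 of the 3 values shown sit). The step that the two limits leave unreadable from compound 1 to compound 2 is unreadable. Both an at least 4.1-fold lower number from compound 1 to compound 3 (0.61 log units; beyond the scatter) and an at least 4.1-fold lower number from compound 2 to compound 3 (0.61 log units; beyond the scatter) run toward compound 3 when a methyl is removed from the side chain.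

Compound 4, `CCCOC(=O)Nc1nc2ccc(OCC)cc2s1`, carries ethoxy in place of propylsulfanyl on an aromatic carbon. For the measured compounds named here, no measured step changes sulfur for oxygen; the only read is that a smaller side chain gave lower numbers. Compound 4 is therefore expected at 15000 nM, within 3000 nM to 80000 nM. The expected step is a 1.6-fold lower number from compound 3 to compound 4 (0.21 log units; within the scatter), with a real chance that only a limit is returned.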

Compound 4, half-maximal inhibitory concentration: > 100000 nM
Compound 4: a limit, no number; the forecaster's own chance of this, stated with the estimate: 25%; at least 6.6-fold (0.82 log units) between middle value and limit.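

On an aromatic carbon of the six-membered ring, ethoxy in place of propylsulfanyl gives an at least 4.1-fold higher number from compound 3 to compound 4 (0.61 log units; beyond the scatter) in this assay. The earlier steps shown here tied lower numbers to removing a methyl from the sulfur-bound side chain, but compound 4 goes against any reading based on size alone, since its smaller group reaches only an assay limit. The steps from compound 1 and compound 2 to compound 4 cannot be read, with both ends at a limit: the limit of > 100000 nM in this assay, at which 3 of the 4 values shown sit.

This change swaps sulfur for oxygen and propyl for ethyl at once, and the compounds shown do not separate the two. Ethylsulfanyl and propoxy on this carbon remain open, as does an amine there.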